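Trading a 3-Methylphenyl for a 1H-Indol-4-yl Group

This account rests on a few compounds, and the source may have more. Where it says the series, first, only, none or still open, it means among the compounds named here.

Compound 1 `COc1ccccc1OC1CCN(c2ccc(-n3ccnc3)nn2)CC1`: 543 nM
Compound 2 `Cc1cccc(OC2CCN(c3ccc(-n4ccnc4)nn3)CC2)c1`: 251 nM

Both compounds were tested in an assay on microsomes from liver for inhibition of acyl-CoA desaturase 1 (Rattus norvegicus); a lower number here means a stronger inhibitor, a higher number a weaker inhibitor. Compound 1 gives 543 nM, and compound 2 gives 251 nM, the lowest number of the two measured here. For the measured compounds named here, the single measured step, a 2.2-fold lower number from compound 1 to compound 2 (0.34 log units; beyond the scatter), swaps one aromatic group for another on an oxygen on a saturated carbon and lowers the number modestly.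

Going by the values given here, compound 3 `c1cc(OC2CCN(c3ccc(-n4ccnc4)nn3)CC2)c2cc[nH]c2c1` keeps the shared core and changes only that same aromatic group: 1H-indol-4-yl in place of 3-methylphenyl on an oxygen on a saturated carbon. The step from compound 1 to compound 2 is the only one that bears on this position, and it shows that changing the aromatic group there moves the number only modestly. Nothing measured here involves a group with a hydrogen-bond donor at this position, so the direction is open. For compound 3 the expected result is therefore a change no larger than the scatter, a 1.0-fold lower number from compound 2 to compound 3 (0.00 log units; within the scatter), with a wide range. The estimate for compound 3 in this assay is 250 nM, between 80 nM and 800 nM.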

Compound 3, half-maximal inhibitory concentration: 162 nM
For compound 3 the middle estimate is 1.5-fold (0.19 log units) above the measured one; low and high end bracket the measured number.
By their numbers in this assay, from the lowest: compounds 3 and 2 (each within the scatter of the next); then compound 1.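

In this assay, replacing 3-methylphenyl with 1H-indol-4-yl on an oxygen on a saturated carbon gives a 1.5-fold lower number from compound 2 to compound 3 (0.19 log units; within the scatter), so a group with a second aromatic ring and a hydrogen-bond donor fits this position, and the number cannot be told apart from that of the simpler group. Measured against 2-methoxyphenyl, the same group gives a 3.4-fold lower number from compound 1 to compound 3 (0.53 log units; beyond the scatter), so compound 1 now stands apart from both compound 2 and compound 3, and this position has shown a real difference between aromatic groups twice, each time with compound 1 as the higher number. No supporting data are available to explain these numbers, and the pair alone cannot show whether the hydrogen on the ring nitrogen matters at all, since the ring system changes along with it.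

Still open, on these data alone, is what happens when that hydrogen on the ring nitrogen is replaced by a methyl group while the rest of the 1H-indol-4-yl group stays in place, which would separate the donor from the added ring. Also open, as far as these compounds go, is how this position responds to a non-aromatic group, such as a chain carrying an amine or a carboxylic acid.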